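A few compounds are considered here, and "the series" means these few. Any claim that something is new, unique, unknown or untested is made for them only; others in the source may bear on it.

Measured in a functional assay on THP-1 cells (Homo sapiens) for inhibition, read by sulforhodamine B assay, with a stated time of 48 h; on this read-out lower numbers stand for stronger inhibition and higher numbers for weaker inhibition:
- compound 1 (`COC(=O)[C@H]1C[C@@H](c2coc3ccccc3c2=O)N(c2ccccc2)O1`) gives > 60000 nM, a limit of the assay
- compound 2 (`O=c1c([C@@H]2C[C@H](c3ccccc3)ON2c2ccccc2)coc2ccccc12`) gives > 60000 nM, a limit of the assay
- compound 3 (`O=c1c([C@@H]2C[C@H](c3ccncc3)ON2c2ccccc2)coc2ccccc12`) gives 16400 nM, a true number

Compound 3 is the only one of the three with an actual number, while the other two rest at one shared limit (the limit of > 60000 nM in this assay, at which 2 of the 3 values shown sit). The next compound, compound 4 (`NC(=O)[C@H]1C[C@@H](c2coc3ccccc3c2=O)N(c2ccccc2)O1`), carries carbamoyl in place of pyridin-4-yl on a saturated ring carbon.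

Among the measured compounds shown here, two measured steps bear on this change, and both end at pyridin-4-yl. Replacing methoxycarbonyl gave an at least 3.6-fold lower number from compound 1 to compound 3 (0.56 log units; beyond the scatter), and replacing phenyl gave an at least 3.6-fold lower number from compound 2 to compound 3 (0.56 log units; beyond the scatter). Both lie beyond the scatter, and each is a minimum, since each starts from a limit. For the measured compounds named here, compound 3 is thus the only compound here with a measurable effect, and compound 4 gives up the group that sets it apart. Carbamoyl does not appear in any measured compound, so this reasoning is indirect. A modest move to a higher number, meaning weaker inhibition, is therefore expected in this assay. The expected change is a 2.7-fold higher number from compound 3 to compound 4 (0.44 log units; beyond the scatter). Compound 4 is estimated at about 45000 nM, with an expected range from 20000 nM to 100000 nM, and it may well return only a limit.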

Compound 4, half-maximal inhibitory concentration: > 60000 nM
Compound 4: no number, only a limit; the forecaster's own chance of this, stated with the estimate: 60%; middle value at least 1.3-fold (0.12 log units) from the limit.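

Putting carbamoyl in place of pyridin-4-yl on the saturated ring carbon next to the ring oxygen gives an at least 3.6-fold higher number from compound 3 to compound 4 (0.56 log units; beyond the scatter) in this assay. Among the compounds shown here, this is the first step that leaves pyridin-4-yl for a small group with no ring, and it shows that such a group does not keep the measurable inhibition of compound 3. Among the four compounds, pyridin-4-yl is now the only group at this place that yields an actual number, while the steps to compound 4 from compound 1 and compound 2 cannot be read and methoxycarbonyl, phenyl and carbamoyl cannot be ranked against one another, all three resting at one shared limit: the limit of > 60000 nM in this assay, at which 3 of the 4 values shown sit.

The compounds shown leave open whether the effect depends on where the nitrogen lies in the aromatic ring, which pyridin-3-yl or pyridin-2-yl on the same carbon would test. They also leave open whether a carboxylic acid or a short chain ending in an amine at this place would give a true number, and how such a number would compare with that of compound 3.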